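Fluorine Position Swap on the Benzyl Group of Compound 1

A few compounds are considered here, and "the series" means these few. Any claim that something is new, unique, unknown or untested is made for them only; others in the source may bear on it.

Compound 1 `O=C1/C(=C/c2ccccc2F)CN(C(=S)SCc2cn(Cc3ccc(F)cc3)nn2)C/C1=C\c1ccccc1F` sits at the limit of a functional assay on PC-3 cells (Homo sapiens) for cytotoxicity, read by MTT assay, with a stated time of 24 h; on this read-out lower numbers stand for stronger inhibition and higher numbers for weaker inhibition: the recorded figure of > 80000 nM is a limit, not a number (the limit of > 80000 nM in this assay, at which 1 of the 2 values shown sits). Compound 2 `Cc1ccc(/C=C2\CN(Cc3cn(Cc4ccccc4F)nn3)C/C(=C\c3ccc(C)cc3)C2=O)cc1` gives 8800 nM in this assay. Compound 3 `O=C1/C(=C/c2ccccc2F)CN(C(=S)SCc2cn(Cc3ccccc3F)nn2)C/C1=C\c1ccccc1F` differs from compound 1 only on the saturated chain carbon bound to an aromatic nitrogen (2-fluorophenyl in place of 4-fluorophenyl on a saturated chain carbon bound to an aromatic nitrogen); the two share every atom, joined differently. Among the measured compounds shown here, no measured step between close pairs is available, so the change is expected to move the read-out little, if at all, beyond the scatter, and the step is expected to be a step that the limit leaves unreadable from compound 1 to compound 3. Compound 3 is estimated at 100000 nM, with a range from 30000 nM to 300000 nM, most likely again reported as a limit.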

Compound 3, half-maximal inhibitory concentration: > 80000 nM
Compound 3 gave a limit, no number; the forecaster's own chance of this, stated with the estimate: 70%; the middle value does not contradict the limit.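

No step can be read from compound 1 to compound 3, as both values are limits, not numbers: the limit of > 80000 nM in this assay, at which 2 of the 3 values shown sit.

Still open, as far as these compounds go, is whether 2-fluorophenyl in place of 4-fluorophenyl changes the read-out at all, since neither compound has a number in this assay.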